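Fluoro in place of hydrogen on the thiourea series

The source may hold more compounds than are shown below. What is called first, only, known or untested is meant among the compounds shown, and "the series" means these compounds.

Values in an ADME assay on MDBK cells (Bos taurus) for cytotoxicity, read by MTT assay, with a stated time of 96 h; on this read-out lower numbers stand for higher toxicity in this test and higher numbers for lower toxicity in this test:
- compound 1 `O=[N+]([O-])c1ccc(NC(=S)Nc2cccc(C(F)(F)F)c2)cc1`: 10000 nM
- compound 2 `FC(F)(F)c1cccc(NC(=S)Nc2ccccc2)c1`: 49000 nM
- compound 3 `Fc1ccc(NC(=S)Nc2cccc(C(F)(F)F)c2)cc1`: not yet measured

Compound 2 holds the higher number of the two measured compounds, at 49000 nM. Compound 3 has fluoro in place of hydrogen on an aromatic carbon, para to a large group: fluoro in place of hydrogen on an aromatic carbon. Among the measured compounds shown here, the only measured step that bears on this is a 4.9-fold higher number from compound 1 to compound 2 (0.69 log units; beyond the scatter), a modest step that replaces nitro with hydrogen. It involves a different group, so it is only a loose guide. A smaller step toward a lower number is expected in this assay, possibly within the scatter. The expected step is a 1.5-fold lower number from compound 2 to compound 3 (0.19 log units; within the scatter). For compound 3 the estimate is 32000 nM, with an expected range of 13000 nM to 65000 nM.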

Compound 3, half-maximal cytotoxic concentration: 41000 nM
For compound 3 the middle estimate is 1.3-fold (0.11 log units) below the measured one; the range from low to high includes it.
By their numbers in this assay, from the lowest: compound 1; then compounds 3 and 2 (each within the scatter of the next).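

In this assay, fluoro in place of hydrogen on this aromatic carbon, para to a large group, gives a 1.2-fold lower number from compound 2 to compound 3 (0.08 log units; within the scatter), so compound 2 and compound 3 cannot be told apart here. Fluoro in place of nitro gives a 4.1-fold higher number from compound 1 to compound 3 (0.61 log units; beyond the scatter), which leaves compound 1 as the only one of the three set apart by its group at this position. No available data explain this difference.

From the compounds shown here alone, it remains open whether an amine, a methoxy group or a carboxylic acid at this position would stay with compound 2 and compound 3 or fall nearer compound 1.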